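A few compounds are considered here, and "the series" means these few. Any claim that something is new, unique, unknown or untested is made for them only; others in the source may bear on it.

Three compounds have been measured in a functional assay on HCT-116 cells (Homo sapiens) for cytotoxicity, read by sulforhodamine B assay, with a stated time of 48 h; a lower number here means a stronger inhibitor, a higher number a weaker inhibitor:
Compound 1, `CCCCNC(=O)N1Cc2c(NC(=O)c3ccc(C)cc3)nn(C(=O)C3CC3)c2C1`, gives 17600 nM.
Compound 2, `CCCCNC(=O)N1Cc2c(NC(=O)c3ccc(C)cc3)nn(C(=O)c3ccccc3)c2C1`, gives 23200 nM.
Compound 3, `CCCCNC(=O)N1Cc2c(NC(=O)c3ccc(OC)cc3)nn(C(=O)C3CC3)c2C1`, gives 65500 nM.

All three share one core, and compound 2 and compound 3 each differ from compound 1 in a single place. Compound 2 carries phenyl in place of cyclopropyl on a carbonyl carbon; in this assay this gave a 1.3-fold higher number from compound 1 to compound 2 (0.12 log units; within the scatter), so the two numbers cannot be told apart. Compound 3 carries methoxy in place of methyl on an aromatic carbon; this gave a 3.7-fold higher number from compound 1 to compound 3 (0.57 log units; beyond the scatter), a modest step toward the weaker side.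

Compound 4, `CCCCNC(=O)N1Cc2c(NC(=O)c3ccc(OC)cc3)nn(C(=O)c3ccccc3)c2C1`, has not yet been measured. It differs from compound 3 by phenyl in place of cyclopropyl on a carbonyl carbon. For the measured compounds named here, this is the same change as the one from compound 1 to compound 2, at the same place, now made on the core that already carries the methoxy group of compound 3. Going by the values given here, that single earlier step is the only guide. Because a 1.3-fold higher number from compound 1 to compound 2 (0.12 log units; within the scatter) stayed within the scatter, the expected step for compound 4 is a 1.3-fold higher number from compound 3 to compound 4 (0.11 log units; within the scatter). The estimate for compound 4 in this assay is therefore 85000 nM, with a likely range from 40000 nM to 180000 nM.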

Compound 4, half-maximal inhibitory concentration: 25300 nM
Compound 4: the middle estimate sits 3.4-fold (0.53 log units) above what was measured, and the stated range ends above it.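

In this assay, the change from cyclopropylcarbonyl to benzoyl did not behave alike on the two cores: with the methoxy group in place it gave a 2.6-fold lower number from compound 3 to compound 4 (0.41 log units; beyond the scatter), a step that does not match the earlier one: the same change on two cores in this assay, a 1.3-fold higher number (0.12 log units; within the scatter) from compound 1 to compound 2 and a 2.6-fold lower number (0.41 log units; beyond the scatter) from compound 3 to compound 4, 3.4-fold (0.53 log units) apart, beyond the scatter of two such steps. Read the other way, methoxy in place of methyl on an aromatic carbon gave a 1.1-fold higher number from compound 2 to compound 4 (0.04 log units; within the scatter) among the benzoyl compounds, which also does not match its earlier step: the same change on two cores in this assay, a 3.7-fold higher number (0.57 log units; beyond the scatter) from compound 1 to compound 3 and a 1.1-fold higher number (0.04 log units; within the scatter) from compound 2 to compound 4, 3.4-fold (0.53 log units) apart, beyond the scatter of two such steps. Both comparisons rest on the same four compounds, so they show a single case in which the two changes do not simply add up, and a step measured on one core could not be carried unchanged to the other; they do not show why, or how general this is across the series.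

As far as these compounds go, it remains open whether the same mismatch appears with other groups on that carbonyl carbon, such as ethyl or pyridyl. From the compounds shown here alone, it is equally open whether it appears with chlorine or a hydroxyl group in place of the methoxy group.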